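Swapping the thiophene on a chlorophenyl arm of a USP7 inhibitor

This account rests on a few compounds, and the source may have more. Where it says the series, first, only, none or still open, it means among the compounds named here.

Measured so far, in an assay on isolated protein for inhibition of ubiquitin carboxyl-terminal hydrolase 7 (Homo sapiens), with stated times of 30 min and 2 h; on this read-out lower numbers stand for stronger inhibition and higher numbers for weaker inhibition:
compound 1 `Cn1nc2c(=O)n(CC3(O)CCN(Cc4ccc(-c5ncco5)cc4Cl)CC3)cnc2c1-c1ccc(CN)cc1` gives 1120 nM
compound 2 `Cn1nc2c(=O)n(CC3(O)CCN(Cc4ccc(C5=CCCC5)cc4Cl)CC3)cnc2c1-c1ccc(CN)cc1` gives 76.9 nM
compound 3 `Cn1nc2c(=O)n(CC3(O)CCN(Cc4ccc(-c5ccsc5Cl)cc4Cl)CC3)cnc2c1-c1ccc(CN)cc1` gives 453 nM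

The three compounds share one core and differ only in the small ring hanging from the chlorophenyl arm. Compound 3 stands second highest of these three numbers: compound 1 gives the highest, and the gap between them is a modest one, seen in a 2.5-fold lower number from compound 1 to compound 3 (0.39 log units; beyond the scatter). Compound 2 gives the lowest number, and the step of a 5.9-fold higher number from compound 2 to compound 3 (0.77 log units; beyond the scatter) shows how much weaker compound 3 is than that. The largest movement is a 15-fold lower number from compound 1 to compound 2 (1.16 log units; beyond the scatter), which shows that this position tolerates wide swings.

Among the measured compounds shown here, compound 4 `Cc1ccc(-c2ccc(CN3CCC(O)(Cn4cnc5c(-c6ccc(CN)cc6)n(C)nc5c4=O)CC3)c(Cl)c2)s1` keeps everything else and changes only this ring: 5-methylthiophen-2-yl in place of 2-chlorothiophen-3-yl on an aromatic carbon. Both rings are thiophenes of the same size, so the change is smaller than the ones already measured. The steps of a 15-fold lower number from compound 1 to compound 2 (1.16 log units; beyond the scatter) and a 5.9-fold higher number from compound 2 to compound 3 (0.77 log units; beyond the scatter) suggest that a more carbon-rich ring here tends to go with a lower number, so a modest lowering is expected, a 2.1-fold lower number from compound 3 to compound 4 (0.31 log units; beyond the scatter), while a change within the scatter cannot be ruled out. Compound 4 is therefore estimated at 220 nM, within a range from 70 nM to 700 nM.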

Compound 4, half-maximal inhibitory concentration: 101 nM
The estimate for compound 4 lay 2.2-fold (0.34 log units) above the measured number; low and high end bracket the measured number.
By their numbers in this assay, from the lowest: compounds 2 and 4 (each within the scatter of the next); then compound 3; then compound 1.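

Two thiophene rings with the same count of heavy atoms are separated in this assay by a 4.5-fold lower number from compound 3 to compound 4 (0.65 log units; beyond the scatter), so being a thiophene does not by itself fix the number at this position; the 5-methylthiophen-2-yl ring has a methyl group in place of the chlorine of 2-chlorothiophen-3-yl and is also joined through a different ring carbon. With a 1.3-fold higher number from compound 2 to compound 4 (0.12 log units; within the scatter), the aromatic 5-methylthiophen-2-yl ring and the non-aromatic cyclopent-1-en-1-yl ring cannot be told apart here, while an 11-fold lower number from compound 1 to compound 4 (1.04 log units; beyond the scatter) shows that 1,3-oxazol-2-yl remains well separated from this thiophene, so aromatic rings on this carbon can give very different numbers. Nothing available here explains why these rings differ.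

The compounds shown leave open whether the methyl group, the loss of the chlorine or the changed point of attachment accounts for the step between the two thiophenes, a question that a plain thiophen-2-yl ring or a 5-chlorothiophen-2-yl ring could help to settle. They also leave open how a ring carrying an amine or a carboxylic acid would behave at this position.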